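A Chloro Group Added to the Core of Compound 1

The compounds below may be only part of what the source reports. "The series", "measured", "known", "first", "only" and "open" are said of these compounds alone.

Among the measured compounds shown here, compound 1 (`FC(F)(F)c1ccnc(N2CCC(NC(=S)Nc3cccnc3)CC2)c1`) stands lowest of the two numbers so far obtained in an assay on membranes from brain for binding affinity to Lysophosphatidylserine lipase ABHD12 (Mus musculus), read by fluorescence, with a stated time of 20 min (a higher number here means a weaker inhibitor, a lower number a stronger inhibitor), where compound 1 gives 640 nM. Its nearest neighbour is compound 2 (`S=C(Nc1cccnc1)NC1CCN(c2cc(OCC3CC3)ccn2)CC1`), which in this assay gives 4700 nM; that step, a 7.3-fold higher number from compound 1 to compound 2 (0.87 log units; beyond the scatter), comes with cyclopropylmethoxy in place of trifluoromethyl on an aromatic carbon and is beyond the scatter.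

Compound 3 (`FC(F)(F)c1cc(Cl)nc(N2CCC(NC(=S)Nc3cccnc3)CC2)c1`) is not yet measured. It differs from compound 1 by chloro in place of hydrogen on an aromatic carbon, the new group sitting on an aromatic carbon of a six-membered aromatic ring with one nitrogen, next to the ring nitrogen and meta to the trifluoromethyl group. For the measured compounds named here, the only measured step, the swap of trifluoromethyl for cyclopropylmethoxy, does not bear on adding a small group at a different aromatic carbon while the trifluoromethyl stays. No guidance on this change exists among the measured compounds, so a step of no more than the usual scatter is expected in either direction, with wide uncertainty. Compound 3 is therefore estimated at 550 nM, with a range from 150 nM to 2000 nM. The expected step is a 1.2-fold lower number from compound 1 to compound 3 (0.07 log units; within the scatter).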

Compound 3, half-maximal inhibitory concentration: 540 nM
For compound 3 the middle estimate is 1.0-fold (0.01 log units) above the measured one; the measured number falls inside the stated range.
By their numbers in this assay, from the lowest: compounds 3 and 1 (each within the scatter of the next); then compound 2.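

In this assay, chloro in place of hydrogen on this aromatic carbon, next to the ring nitrogen and meta to the trifluoromethyl group, gives a 1.2-fold lower number from compound 1 to compound 3 (0.07 log units; within the scatter), so the added chlorine does not separate compound 3 from compound 1. Among the compounds shown here, the earlier step, a 7.3-fold higher number from compound 1 to compound 2 (0.87 log units; beyond the scatter), changed the group at the trifluoromethyl site itself, whereas this result is the first reading on a second aromatic carbon of that ring, and it shows that this carbon can carry a chloro group with the trifluoromethyl group in place and the number staying within the scatter. Nothing measured on these compounds offers an explanation for this result.

The compounds shown leave open whether this carbon accepts anything other than chloro, such as a methyl group, a methoxy group, an amine or a nitrile, since a single group at one position says little about what else would fit there. They also leave open whether chloro at this carbon would give a similar step with cyclopropylmethoxy in place of trifluoromethyl, as in compound 2.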